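Spiro core series: amine substituent variation and sigma-1 binding

The compounds below may be only part of what the source reports. "The series", "measured", "known", "first", "only" and "open" are said of these compounds alone.

Measured compounds:
compound 1, `COC1Cc2sccc2C2(CCN(CCC(C)C)CC2)O1`, 1 nM
compound 2, `COC1Cc2sccc2C2(CCN(CC=C(C)C)CC2)O1`, 1 nM

In an assay on membranes from brain for displacement of a labelled ligand from Sigma non-opioid intracellular receptor 1 (Cavia porcellus) (on this read-out lower numbers stand for stronger inhibition and higher numbers for weaker inhibition), compound 1 gives 1 nM. Compound 2 carries 2-methylprop-1-en-1-yl in place of isobutyl on a saturated chain carbon bound to an amine nitrogen in a ring, and in this assay compound 2 gives 1 nM. Among the compounds with values here, the only measured step, no change at the digits printed from compound 1 to compound 2 (within the scatter), shows that this exchange leaves the read-out unchanged within the scatter, so compound 2 stands level with compound 1.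

Compound 3, `CCCCCCCCN1CCC2(CC1)OC(OC)Cc1sccc12`, has not been measured in this assay. It differs from compound 2 as follows: heptyl in place of 2-methylprop-1-en-1-yl on a saturated chain carbon bound to an amine nitrogen in a ring. Within the data shown here, the step from compound 1 to compound 2 bears on this only in part: it shows that reshaping a four-carbon group at this place made no difference, but no measured pair covers a longer chain such as heptyl, so the effect of the added length is unknown.

Given this, the expected step of a 1.5-fold higher number from compound 2 to compound 3 (0.18 log units; within the scatter) is small, of either sign. Compound 3 is therefore estimated to give 1.5 nM in this assay, with a range from 0.4 nM to 6 nM.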

Compound 3, inhibition constant: 5.1 nM
Beside the measured number, compound 3's estimate is 3.4-fold (0.53 log units) below it; the range from low to high includes it.
By their numbers in this assay, from the lowest: compounds 1 and 2 (each within the scatter of the next); then compound 3.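

The amine substituent is not a silent position: the exchange between the branched groups of compound 1 and compound 2 left the number in this assay unchanged, but the straight heptyl replacement gives a 5.1-fold higher number from compound 2 to compound 3 (0.71 log units; beyond the scatter), and the comparison with the saturated partner gives a 5.1-fold higher number from compound 1 to compound 3 (0.71 log units; beyond the scatter). Both steps lie beyond the scatter and are of the same size, so the presence or absence of the double bond in the branched group makes no difference to how far compound 3 stands from either compound, and the change is modest, with compound 3 still giving 5.1 nM. Nothing at hand explains the loss on going to the longer straight chain.

Compound 3 differs from compound 1 and compound 2 in both chain length and branching, so these compounds cannot show which of the two carries the step; a straight butyl or pentyl chain, or a branched chain as long as heptyl, would separate them. On these data alone, whether the number keeps rising with chain length beyond octyl, or how a benzyl or phenethyl group on the same amine nitrogen compares, also stays open.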